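A few compounds are considered here, and "the series" means these few. Any claim that something is new, unique, unknown or untested is made for them only; others in the source may bear on it.

Working notes on the series.

Three compounds have numbers in an assay for inhibition of Alpha amylase (Homo sapiens), with a stated time of 10 min; on this read-out higher numbers stand for weaker inhibition and lower numbers for stronger inhibition. Compound 1 `Oc1ccc(-c2nc3cc(F)ccc3[nH]2)c(O)c1` gives 2980 nM in this assay. Compound 2 `COc1ccc(-c2nc3cc(F)ccc3[nH]2)c(F)c1` gives 1590 nM in this assay. Compound 3 `Oc1c(Br)cc(Cl)cc1-c1nc2cc(Cl)ccc2[nH]1` gives 2860 nM in this assay. Compound 2 carries the smallest number of the three, but its differences to compound 3 and to compound 1 both fall within the usual scatter, so nothing separates the three on the numbers shown. Going by the values given here, no pair among them differs in only one place, so no single structural step has a measured size in this assay.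

Compound 4 `COc1ccc(-c2nc3cc([N+](=O)[O-])ccc3[nH]2)c(F)c1` is not yet measured. It differs from compound 2 in one place: nitro in place of fluoro on an aromatic carbon. The methoxy and the fluoro on the pendant ring are kept, and the change sits on the core shared by all four compounds.

There is no measured step of this kind in the series, so the size of the step from compound 2 to compound 4 cannot be read from other pairs. With the three measured numbers standing level with one another, the expectation is a step of a 1.0-fold higher number from compound 2 to compound 4 (0.00 log units; within the scatter), that is, none beyond the scatter in either direction. Compound 4 is estimated at 1600 nM, with a range from 500 nM to 5000 nM.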

Compound 4, half-maximal inhibitory concentration: 2750 nM
Compound 4: middle estimate off by 1.7-fold (0.24 log units), on the low side, and the stated range covers the measured number.
By their numbers in this assay, from the lowest: compounds 2, 4, 3 and 1 (each within the scatter of the next).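

Going by these compounds alone, this position on the shared core now has a measured step, which the earlier compounds did not supply: in this assay, nitro in place of fluoro on an aromatic carbon gives a 1.7-fold higher number from compound 2 to compound 4 (0.24 log units; within the scatter). The entering nitro counts 3 heavy atoms and 2 hydrogen-bond acceptors against 1 heavy atom and 0 hydrogen-bond acceptors for the leaving fluoro, yet compound 2 and compound 4 cannot be told apart on this read-out, so this exchange of groups at this position shows no effect beyond the scatter. No measurement of any property of these two groups accompanies the result, and nothing here accounts for it.

Only fluoro and nitro are shown at this position, so it stays open whether another group there, such as an amine, a carboxylic acid or a longer chain, would give a step beyond the scatter. On these data alone, it also stays open whether the same exchange would keep its size with the hydroxyl-bearing pendant ring of compound 1 in place of the methoxy and fluoro ring kept in compound 2 and compound 4.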